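The source may hold more compounds than are shown below. What is called first, only, known or untested is meant among the compounds shown, and "the series" means these compounds.

Measured compounds:
Compound 1 `CCOc1ccc(Cc2nnc(CN(c3cccc(Cl)c3Cl)S(=O)(=O)c3ccc(C)cc3)o2)cc1` gives 6.31 nM in an assay on CHO cells for displacement of a labelled ligand from prostaglandin E2 receptor EP1 subtype (Homo sapiens); on this read-out higher numbers stand for weaker inhibition and lower numbers for stronger inhibition.
Compound 2 `COc1ccc(Nc2nnc(CN(c3cccc(Cl)c3C)S(=O)(=O)c3ccc(C)cc3)o2)cc1` gives 31.6 nM in this assay.

Of the two numbers, compound 2 holds the higher one; compound 1 stands at a lower value, and the gap between them lies beyond the scatter. The two compounds differ in more than one place, so no single step can be read from them.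

Compound 3 `COc1ccc(Nc2nnc(CN(c3cccc(Cl)c3Cl)S(=O)(=O)c3ccc(C)cc3)o2)cc1` is compound 2 with chloro in place of methyl on an aromatic carbon. Compound 3 thus carries the same 2,3-dichlorophenyl group as compound 1 while keeping the rest of compound 2. Going by the values given here, with no directly comparable pair measured, the size of the step in this assay is uncertain, but a modest move toward lower numbers is expected, given that compound 1, the only measured compound carrying the chloro group at this place, shows 6.31 nM. Compound 3 is expected to give about 18 nM, within 7 nM to 50 nM. The expected step is a 1.8-fold lower number from compound 2 to compound 3 (0.24 log units; within the scatter).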

Compound 3, half-maximal inhibitory concentration: 39.8 nM
Compound 3: the middle estimate sits 2.2-fold (0.34 log units) below what was measured, within the range that was stated.
By their numbers in this assay, from the lowest: compound 1; then compounds 2 and 3 (each within the scatter of the next).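

In this assay, chloro in place of methyl on this aromatic carbon, 3-chloro-2-methylphenyl to 2,3-dichlorophenyl, gives a 1.3-fold higher number from compound 2 to compound 3 (0.10 log units; within the scatter), so the two groups are not told apart here, at least with the (4-methoxyphenyl)amino group in place. With the 2,3-dichlorophenyl group held constant, (4-methoxyphenyl)amino in place of 4-ethoxybenzyl gives a 6.3-fold higher number from compound 1 to compound 3 (0.80 log units; beyond the scatter), which places a difference beyond the scatter at that other site rather than at the chloro position. Nothing available explains either result.

On these data alone, the second step replaces 4-ethoxybenzyl as a whole, so the separate shares of methoxy against ethoxy and of the amino group against the methylene remain open. Also open, as far as these compounds go, is whether a fluoro or methoxy group at the chloro position would behave the same way.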